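Methyl in place of methoxy: acid dissociation working notes

A few compounds are considered here, and "the series" means these few. Any claim that something is new, unique, unknown or untested is made for them only; others in the source may bear on it.

Measured in an ADME assay, so far:
compound 1, `COc1ccc(S(=O)(=O)Nc2cccc([N+](=O)[O-])c2)cc1`: 8.44
compound 2, `Cc1ccc(S(=O)(=O)Nc2cccc([N+](=O)[O-])c2)cc1`: 8.27
compound 3, `COc1ccc(S(=O)(=O)Nc2ccc(F)cc2)cc1`: 9.32

Between compound 1 and compound 2 the only difference is methyl in place of methoxy on an aromatic carbon. The step of a number 0.17 log units lower from compound 1 to compound 2 (within the scatter) lies within the scatter, so the two values are not separable here. Compound 3 gives the highest number of the three, beyond the scatter from both compound 1 and compound 2; how its core differs from that of compound 1 is not broken down here.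

Compound 4, `Cc1ccc(S(=O)(=O)Nc2ccc(F)cc2)cc1`, is not yet measured. It differs from compound 3 by methyl in place of methoxy on an aromatic carbon, the same change as between compound 1 and compound 2, at the same place. The step of a number 0.17 log units lower from compound 3 to compound 4 (within the scatter) is therefore expected to be small, resting on a number 0.17 log units lower from compound 1 to compound 2 (within the scatter). Compound 4 is estimated at 9.15, between 8.85 and 9.45.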

Compound 4, acid dissociation constant: 9.2
Compound 4: the middle estimate sits 0.05 log units below what was measured; low and high end bracket the measured number.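

In this assay methyl in place of methoxy gives a number 0.12 log units lower from compound 3 to compound 4 (within the scatter) and so stays as small on the second core as on the first. The two steps cannot be told apart: the same change on two cores in this assay, a number 0.17 log units lower (within the scatter) from compound 1 to compound 2 and a number 0.12 log units lower (within the scatter) from compound 3 to compound 4, 0.05 log units apart, within the scatter of two such steps
This supports carrying the change between the core of compound 1 and the core of compound 3 with little expected movement in the read-out, but it does not show that the change has no effect at all, or that it would hold on any other core.

The compounds shown leave open what other groups at this place, such as an amine, a carboxylic acid or a longer chain, would do to the read-out. As far as these compounds go, whether the step stays this small on a third core also remains open.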